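Replacing a Methylsulfonyl Group with a Carboxymethoxyphenyl Arm

The source may hold more compounds than are shown below. What is called first, only, known or untested is meant among the compounds shown, and "the series" means these compounds.

Of the compounds shown here, three have so far been measured in an in vitro ADME assay on microsomes from liver (Homo sapiens) for metabolic stability; on this read-out higher numbers stand for a longer-lived compound and lower numbers for a shorter-lived compound. Compound 1 `O=C(COc1nnnn1-c1cccc2ccccc12)Nc1ccccc1[N+](=O)[O-]` gives 0.05 h in this assay. Compound 2 `O=C(CCc1nnnn1-c1cccc2ccccc12)Nc1ccccc1[N+](=O)[O-]` gives 0.117 h in this assay. Compound 3 `CC(C)(C)c1ccc(-n2nnnc2SCC(=O)Nc2ccc(S(C)(=O)=O)cc2Cl)c(Cl)c1` gives 0.75 h in this assay, the highest of the three numbers; its gaps to compound 2 and to compound 1 both lie beyond the usual scatter, so compound 3 is the longest-lived compound of the set as it stands. Going by the values given here, compounds 1 and 2 share a different core from compound 3, and no single-point step links any two of the measured compounds.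

Compound 4 `CC(C)(C)c1ccc(-n2nnnc2SCC(=O)Nc2ccc(-c3ccc(OCC(=O)O)cc3)cc2Cl)c(Cl)c1` is the next compound to be measured. It differs from compound 3 in one place: 4-(carboxymethoxy)phenyl in place of methylsulfonyl on an aromatic carbon. Among the compounds with values here, no measured pair shows the effect of this kind of change, so the expectation rests on compound 3 alone and carries wide uncertainty. The step that the estimate means, a 1.3-fold lower number from compound 3 to compound 4 (0.10 log units; within the scatter), is expected to be modest and, if anything, slightly downward, but most likely not beyond the scatter. Compound 4 is therefore expected to give about 0.6 h in this assay, with a plausible range from 0.2 h to 1.8 h.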

Compound 4, half-life: 0.117 h
Compound 4: the middle estimate sits 5.1-fold (0.71 log units) above what was measured; the whole stated range lies above it.
By their numbers in this assay, from the lowest: compound 1; then compounds 2 and 4 (each within the scatter of the next); then compound 3.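

In this assay, going by these compounds alone, putting 4-(carboxymethoxy)phenyl in place of methylsulfonyl on this aromatic carbon, meta to a chloro group, gives a 6.4-fold lower number from compound 3 to compound 4 (0.81 log units; beyond the scatter), the first single-place step in the set. The earlier compounds shown here could not show this, since no two of them differed in one place only; this pair shows that the number responds to what this carbon carries, with the rest of the structure unchanged. The exchange brings in a larger group with a six-membered aromatic ring and a hydrogen-bond donor, but nothing available here bears on why the number falls, so the step describes the whole exchange and cannot be assigned to any one part of it.

The compounds shown leave open which part of the new arm goes with the step: a plain phenyl or a methoxyphenyl on the same carbon would separate the ring from the carboxylic acid and its ether chain. They also leave open how a methyl ester or a primary amide in place of the carboxylic acid, or a longer chain before it, would read on this scaffold.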